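Lengthening the Chain Toward the Hydroxamic Acid

This account rests on a few compounds, and the source may have more. Where it says the series, first, only, none or still open, it means among the compounds named here.

compound 1 `O=C(CCNC(=S)Nc1ccc2c(c1)C(=O)NC2=O)NO`: 18100 nM
compound 2 `O=C(CCCNC(=S)Nc1ccc2c(c1)C(=O)NC2=O)NO`: 12600 nM

Compound 2 gives the lowest of the two numbers in an assay on cells for inhibition of protein deacetylase HDAC6 (Homo sapiens), read by fluorescence, with a stated time of 1 h (on this read-out higher numbers stand for weaker inhibition and lower numbers for stronger inhibition), with compound 1 close by. Compound 3 `O=C(CCCCNC(=S)Nc1ccc2c(c1)C(=O)NC2=O)NO` differs from compound 2 by (hydroxycarbamoyl)methyl in place of hydroxycarbamoyl on a saturated chain carbon, three bonds along the chain from an amide-type nitrogen. Going by the values given here, the only measured step of this kind is a 1.4-fold lower number from compound 1 to compound 2 (0.16 log units; within the scatter), a shift that stays inside the scatter. For compound 3 the change is expected to be of similar size, a 1.4-fold lower number from compound 2 to compound 3 (0.15 log units; within the scatter), a slightly lower number that may well not exceed the scatter. Compound 3 is therefore estimated at 9000 nM, with a range from 3000 nM to 27000 nM.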

Compound 3, half-maximal inhibitory concentration: 14200 nM
For compound 3 the middle estimate is 1.6-fold (0.20 log units) below the measured one, and the stated range covers the measured number.
By their numbers in this assay, from the lowest: compounds 2, 3 and 1 (each within the scatter of the next).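

Adding one more chain carbon gives a 1.1-fold higher number from compound 2 to compound 3 (0.05 log units; within the scatter), and the full lengthening gives a 1.3-fold lower number from compound 1 to compound 3 (0.11 log units; within the scatter). Across all three compounds, then, the added chain carbons produce no difference that exceeds the scatter, so the earlier single step does not grow into a trend. No other measurement here bears on this flat result. From the compounds shown here alone, whether a longer chain, or a carboxylic acid in place of the hydroxycarbamoyl end, would move the number beyond the scatter remains open.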